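Second fluoro on the 4-fluorophenyl group

The source may report more compounds than this note shows. Statements on the series, on what has been measured and on what is new or still open speak of the compounds shown alone.

Measured so far in a functional assay on KB cells (Homo sapiens) for antiproliferative activity; a lower number here means a stronger inhibitor, a higher number a weaker inhibitor
- compound 1 `COc1ccc(S(=O)(=O)N2CCc3cccc(Nc4ccccc4)c32)cc1` gives 342 nM
- compound 2 `COc1ccc(S(=O)(=O)N2CCc3cccc(Nc4ccc(F)cc4)c32)cc1` gives 557 nM

Compound 2 stands within the scatter of compound 1 (a 1.6-fold higher number from compound 1 to compound 2 (0.21 log units; within the scatter)). Compound 3 `COc1ccc(S(=O)(=O)N2CCc3cccc(Nc4ccc(F)c(F)c4)c32)cc1` carries one further change (fluoro in place of hydrogen on an aromatic carbon), turning 4-fluorophenyl into 3,4-difluorophenyl. For the measured compounds named here, the one measured step that bears on this is the same kind of replacement, fluoro in place of hydrogen on an aromatic carbon, and it stayed small (a 1.6-fold higher number from compound 1 to compound 2 (0.21 log units; within the scatter)). On that single precedent, no change beyond the scatter is expected in this assay. The step expected is small (a 1.1-fold lower number from compound 2 to compound 3 (0.03 log units; within the scatter)). Compound 3 is estimated at 520 nM (expected range 240 nM to 1100 nM).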

Compound 3, half-maximal inhibitory concentration: 412 nM
The estimate for compound 3 lay 1.3-fold (0.10 log units) above the measured number; measured number inside the range.
By their numbers in this assay, from the lowest: compounds 1, 3 and 2 (each within the scatter of the next).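

In this assay, a second fluoro ortho to the first leaves the number within the scatter (a 1.4-fold lower number from compound 2 to compound 3 (0.13 log units; within the scatter)), and so does the whole change from phenyl to 3,4-difluorophenyl (a 1.2-fold higher number from compound 1 to compound 3 (0.08 log units; within the scatter)). Across compound 1, compound 2 and compound 3, one or two fluoro groups on this ring therefore give no step beyond the scatter. No supporting measurement is available to explain these small steps.

As far as these compounds go, whether a larger or charged group on this ring, such as an amine or a carboxylic acid, would give a step beyond the scatter remains open. Also open, from the compounds shown here alone, is whether a longer chain in place of the ring on the nitrogen would do so.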